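The source may hold more compounds than are shown below. What is called first, only, known or untested is meant among the compounds shown, and "the series" means these compounds.

Working notes on the series. Compound 1 `Fc1cc(Nc2nc3nonc3nc2Nc2ccc(C(F)(F)F)c(F)c2)ccc1C(F)(F)F` serves as the point of reference: in an assay on mitochondria from L6 cells (Rattus norvegicus) for activation, with a stated time of 90 min (a lower number here means that less compound is needed, a higher number that more compound is needed for the effect), compound 1 gives 1700 nM. Compound 2 `Fc1ccc(C(F)(F)F)cc1Nc1nc2nonc2nc1Nc1cc(C(F)(F)F)ccc1F` returns in this assay only a limit of the assay, < 1000 nM, which is the case recorded as the limit of < 1000 nM in this assay, at which 1 of the 3 values shown sits. Compound 3 `Fc1ccccc1Nc1nc2nonc2nc1NC1CCCCC1` gives 13400 nM in this assay, the highest of the two numbers in hand; the nearest number is that of compound 1, which lies lower by a margin well beyond the usual scatter.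

Compound 4 `COc1cccc(Nc2nc3nonc3nc2Nc2ccccc2F)c1` has not yet been measured. It differs from compound 3 in a single place: 3-methoxyphenyl in place of cyclohexyl on a nitrogen on an aromatic ring. Within the data shown here, no pair of measured compounds differs only at this place, so the size of the step cannot be read off directly. What can be said is that compound 1, which carries a six-membered aromatic ring of carbon only rather than cyclohexyl at this place, stands at 1700 nM, a lower number than compound 3.

On that basis compound 4 is expected to give about 3500 nM in this assay, with a plausible range from 900 nM to 13000 nM. The estimate corresponds to an expected step of a 3.8-fold lower number from compound 3 to compound 4 (0.58 log units; beyond the scatter), a move toward a lower number beyond the scatter, though its size is uncertain.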

Compound 4, half-maximal effective concentration: 830 nM
Beside the measured number, compound 4's estimate is 4.2-fold (0.62 log units) above it; measured number below the stated range.
By their numbers in this assay, from the lowest: compound 4; then compound 1; then compound 3.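

Among these compounds, on the nitrogen on an aromatic ring, 3-methoxyphenyl in place of cyclohexyl gives in this assay the first step that can be read directly at this place, a 16-fold lower number from compound 3 to compound 4 (1.21 log units; beyond the scatter), and it is a large one. The series is therefore shown to respond strongly to what sits on this nitrogen, which the earlier compounds could not show, as no pair among them differed in one place only. No measurement in hand bears on why the number falls with this change.

Going by these compounds, the step also combines several differences in one exchange, the aromatic ring for the non-aromatic one and the added methoxy group, so it remains open how much belongs to each; plain phenyl at this place would separate them, and a ring carrying an amine or a carboxylic acid would extend the comparison. On these data alone, compound 2 at < 1000 nM is a limit of the assay, and its place in the order of the series stays open.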